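The source may hold more compounds than are shown below. What is called first, only, known or untested is meant among the compounds shown, and "the series" means these compounds.

Series notes. Compound 1 `CC(C(=O)N1CCN(c2ccccc2)CC1)N1C(=O)CCC1=O` gives 50% in a functional assay on the whole organism (strain Swiss) with Mus musculus as the target, in the maximal electroshock model, with a stated time of 0.25 h, at a dose of 100 mg/kg by the intraperitoneal route; on this read-out higher numbers stand for a stronger effect at the one dose given and lower numbers for a weaker effect. Compound 3 `CCC(C(=O)N1CCN(c2cccc(Cl)c2)CC1)N1C(=O)CCC1=O` gives 50%, level with compound 1 at the digits shown, and the two together hold the highest of the three numbers. Compound 2 `CCC(C(=O)N1CCN(c2cccc(F)c2)CC1)N1C(=O)CCC1=O` gives 0%, the furthest from compound 1. Within the data shown here, the only measured single-point step is a number 50 percentage points higher from compound 2 to compound 3 (beyond the scatter), a change on an aromatic carbon. Compound 4 `Cc1cccc(N2CCN(C(=O)C(C)N3C(=O)CCC3=O)CC2)c1` differs from compound 1 by methyl in place of hydrogen on an aromatic carbon. Among the measured compounds shown here, this also sits on an aromatic carbon, but no measured step exchanges hydrogen for methyl there, so the fluoro-to-chloro step is only a loose guide. No change beyond the scatter is expected, no change at the digits printed from compound 1 to compound 4 (within the scatter). Compound 4 is estimated at 50%, within 25% to 75%.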

Compound 4, a percentage reported as activity, at one dose (the size of the read-out at that dose, not a potency): 0%
Compound 4: the middle estimate sits 50 percentage points above what was measured, outside the stated range (below it).
By their numbers in this assay, from the lowest: compounds 2 and 4 (each within the scatter of the next); then compounds 1 and 3 (each within the scatter of the next).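

In this assay, going from phenyl to 3-methylphenyl gives a number 50 percentage points lower from compound 1 to compound 4 (beyond the scatter). A single added methyl on an aromatic carbon, meta to a large group, is therefore enough to change this read-out, whereas the earlier step showed only an exchange of fluoro for chloro. No measurement at hand accounts for this result. Still open, from the compounds shown here alone, is whether a methoxy group, an amine or a longer chain on this same carbon would read like hydrogen or like methyl. Also open, going by these compounds, is whether hydrogen to methyl gives a similar step on other members.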